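The compounds below may be only part of what the source reports. "The series", "measured", "known", "first", "only" and "open" are said of these compounds alone.

Measured compounds:
- compound 1, `CCOC(=O)C1=C(C)N/C(=N\C#N)NC1c1ccccc1`: in an assay on HeLa cells for displacement of a labelled ligand from adenosine receptor A3 (Homo sapiens), with a stated time of 180 min, tested at 1 uM (a higher number here means more inhibition at the concentration tested (going by the name of the read-out), a lower number less inhibition), compound 1 gives 13%
- compound 2, `CC1=C(C(=O)OC(C)C)C(C2CCCC2)NC(=O)N1`: in this assay compound 2 gives 7%
- compound 3, `CC1=C(C(=O)OC(C)C)C(c2ccccc2)NC(=O)N1`: in this assay compound 3 gives 2%

Compound 1 holds the highest of the three numbers. Its gap to compound 2 lies within the scatter, so no order between the two is claimed; its gap to compound 3 lies beyond it. The core of compound 1 and the core of compound 3 are not the same, and the difference between the two cores is not broken down here.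

Compound 2 and compound 3 share a core and differ in one place, (cyclopentyl in place of phenyl on a saturated ring carbon). The step from this change is a number 5 percentage points higher from compound 3 to compound 2 (within the scatter).

Compound 4, `CCOC(=O)C1=C(C)N/C(=N\C#N)NC1C1CCCC1`, is not yet measured. It stands to compound 1 as compound 2 stands to compound 3: cyclopentyl in place of phenyl on a saturated ring carbon. The surroundings of the place are not identical: in the measured pair the saturated ring carbon is next to the ring atom that bears an isopropoxycarbonyl group, whereas in the pair with compound 4 it is next to the ring atom that bears an ethoxycarbonyl group. It is therefore the same kind of change, not the same change.

Within the data shown here, on this basis a step of a number 4 percentage points higher from compound 1 to compound 4 (within the scatter) is expected, because the one measured instance of this kind of change gave a number 5 percentage points higher from compound 3 to compound 2 (within the scatter). Compound 4 is accordingly estimated at 17% in this assay, with a range from 5% to 29%.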

Compound 4, a percentage reported as inhibition, at one concentration (the size of the read-out at that concentration, not a potency): 4%
Beside the measured number, compound 4's estimate is 13 percentage points above it; the measured number lies below the stated range.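

In this assay, cyclopentyl in place of phenyl on a saturated ring carbon can now be read on two cores, and the two steps do not separate: the same change on two cores in this assay, a number 5 percentage points higher (within the scatter) from compound 3 to compound 2 and a number 9 percentage points lower (within the scatter) from compound 1 to compound 4, 14 percentage points apart, within the scatter of two such steps

The new step is a number 9 percentage points lower from compound 1 to compound 4 (within the scatter), so on neither core does this change give a step that stands clear of the scatter, and the opposite directions of the two steps carry no weight. This does not show that the change behaves alike on both cores, nor that its outcome depends on the core: two pairs with both steps inside the scatter cannot settle either reading.

Left open is how the read-out responds to a group other than phenyl or cyclopentyl on the saturated ring carbon, such as a longer alkyl chain or a ring carrying an amine, and to a carboxylic acid in place of the ethoxycarbonyl or isopropoxycarbonyl group. Among these compounds, all four numbers come from a single tested concentration, so they give no potency for any compound.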